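Adding Chlorine to Two Related Cores: Expected Solubility

This account rests on a few compounds, and the source may have more. Where it says the series, first, only, none or still open, it means among the compounds named here.

Compound 1, `Clc1ccc(Nc2nc(-c3ncccn3)cs2)nc1`: 20000 nM.
Compound 2, `Clc1ccc(Nc2nc(-c3ncccn3)c(Cl)s2)nc1`: the assay reports only its limit, < 10000 nM.
Compound 3, `Clc1ccc(Nc2nc(-c3cnccn3)cs2)nc1`: the assay reports only its limit, < 10000 nM.

In a physicochemical assay for solubility, in phosphate buffer, with a stated time of 2 h, at pH 7.4 (on this read-out lower numbers stand for lower solubility and higher numbers for higher solubility), compound 1 gives 20000 nM. Compound 2 reaches only a limit, < 10000 nM. Compound 3 likewise reaches only a limit, < 10000 nM. The change chloro in place of hydrogen on an aromatic carbon brought an at least 2.0-fold lower number from compound 1 to compound 2 (0.30 log units; that floor lies within the scatter). The change pyrazin-2-yl in place of pyrimidin-2-yl on an aromatic carbon brought an at least 2.0-fold lower number from compound 1 to compound 3 (0.30 log units; that floor lies within the scatter). Both steps rest on (the limit of < 10000 nM in this assay, at which 2 of the 3 values shown sit).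

Compound 4, `Clc1ccc(Nc2nc(-c3cnccn3)c(Cl)s2)nc1`, is not yet measured. It differs from compound 3 by chloro in place of hydrogen on an aromatic carbon, the same kind of change as from compound 1 to compound 2, though the place differs: the ring atom next to it bears a pyrazin-2-yl group rather than a pyrimidin-2-yl group. Compound 4 is expected to give about 4000 nM, between 1000 nM and 10000 nM. That estimate means a step that the limit leaves unreadable from compound 3 to compound 4, expected because compound 3 already sits at its limit < 10000 nM and the earlier chloro step gave an at least 2.0-fold lower number from compound 1 to compound 2 (0.30 log units; that floor lies within the scatter).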

Compound 4, solubility: < 10000 nM
Compound 4 gave a limit, no number; the forecaster's own chance of this, stated with the estimate: 85%; the middle value is on the limit's open side.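

No new step can be read, since compound 4 also gives only a limit, leaving its comparisons with compound 2 and compound 3 unreadable: the limit of < 10000 nM in this assay, at which 3 of the 4 values shown sit.

The compounds shown leave open how the solubilities of compound 2, compound 3 and compound 4 actually compare.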